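The source may report more compounds than this note shows. Statements on the series, on what has been measured and on what is new or still open speak of the compounds shown alone.

Measured so far:
compound 1 `O=C(c1ccn2c1CSC2c1cccnc1)c1c[nH]c2cc(-c3ccc(F)cc3)ccc12` with 6.4 mg/kg
compound 2 `NCCn1cc(C(=O)c2ccn3c2CSC3c2cccnc2)c2ccc(-c3ccc(F)cc3)cc21` with 1.3 mg/kg

In a functional assay on the whole organism for inhibition, with Rattus norvegicus as the target (a higher number here means that more compound is needed for the effect, a lower number that less compound is needed), compound 2 stands lowest of the two numbers. Among the measured compounds shown here, the only measured step is a 4.9-fold lower number from compound 1 to compound 2 (0.69 log units; beyond the scatter). Compound 3 `O=C(O)CCn1cc(C(=O)c2ccn3c2CSC3c2cccnc2)c2ccc(-c3ccc(F)cc3)cc21` differs from compound 2 by carboxy in place of amino on a saturated chain carbon, two bonds along the chain from an aromatic nitrogen. For the measured compounds named here, no measured step bears on this exchange; the one known step concerns the whole chain being added, not what sits at its end. The direction is therefore open, and compound 3 is expected to give a step of a 2.3-fold higher number from compound 2 to compound 3 (0.36 log units; beyond the scatter), a modest rise in this assay. Compound 3 is estimated at 3 mg/kg, in the range 1 mg/kg to 10 mg/kg.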

Compound 3, dose for half-maximal effect: 5.1 mg/kg
Beside the measured number, compound 3's estimate is 1.7-fold (0.23 log units) below it, and the stated range covers the measured number.
By their numbers in this assay, from the lowest: compound 2; then compounds 3 and 1 (each within the scatter of the next).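

In this assay what sits at the end of the chain counts: carboxy in place of amino gives a 3.9-fold higher number from compound 2 to compound 3 (0.59 log units; beyond the scatter) and so the lower number reached with 2-aminoethyl does not carry over to 2-carboxyethyl. On the aromatic nitrogen, 2-carboxyethyl in place of hydrogen gives a 1.3-fold lower number from compound 1 to compound 3 (0.10 log units; within the scatter) and thus no change beyond the scatter. Nothing available explains this difference between the two chain ends. Still open, from the compounds shown here alone, is whether a longer chain ending in an amine, or a chain ending in a hydroxyl group, would match compound 2.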